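Series notes: anilino in place of 4-carboxyphenyl

A few compounds are considered here, and "the series" means these few. Any claim that something is new, unique, unknown or untested is made for them only; others in the source may bear on it.

compound 1 (`Cc1ccc(S(=O)(=O)N/N=C2\C(=O)Nc3ccc(S(=O)(=O)N4CCOCC4)cc32)cc1`) at 24700 nM
compound 2 (`O=C1Nc2ccc(S(=O)(=O)N3CCOCC3)cc2/C1=N/c1ccc(C(=O)O)cc1`) at 23100 nM

Compound 2 gives 23100 nM in a functional assay on HepG2 cells (Homo sapiens) for cytotoxicity, read by sulforhodamine B assay, with a stated time of 24 h (on this read-out higher numbers stand for weaker inhibition and lower numbers for stronger inhibition), and sits within the usual scatter of compound 1, so the two values cannot be told apart. Compound 3 (`O=C1Nc2ccc(S(=O)(=O)N3CCOCC3)cc2/C1=N/Nc1ccccc1`) is not yet measured. It carries anilino in place of 4-carboxyphenyl on a double-bonded nitrogen. For the measured compounds named here, no measured step covers this change. The expectation rests only on compound 1 at 24700 nM and compound 2 at 23100 nM staying within the scatter of each other although their structures differ at that place. A small move toward stronger inhibition, not clearly beyond the scatter, is expected in this assay (a 1.5-fold lower number from compound 2 to compound 3 (0.19 log units; within the scatter)). For compound 3 the estimated value is 15000 nM (expected range 5000 nM to 40000 nM).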

Compound 3, half-maximal inhibitory concentration: 15600 nM
Estimate against measurement, compound 3: 1.0-fold (0.02 log units) below; low and high end bracket the measured number.
By their numbers in this assay, from the lowest: compounds 3, 2 and 1 (each within the scatter of the next).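

In this assay, anilino in place of 4-carboxyphenyl on a double-bonded nitrogen gives a 1.5-fold lower number from compound 2 to compound 3 (0.17 log units; within the scatter), a step within the scatter, so removing the 4-carboxyphenyl group produces no readable shift at this place. Phenyl in place of (4-methylphenyl)sulfonyl on an amine nitrogen gives a 1.6-fold lower number from compound 1 to compound 3 (0.20 log units; within the scatter), also within the scatter, so the sulfonyl-bearing group of compound 1 likewise cannot be told apart from the plain phenyl of compound 3. Nothing measured on these compounds accounts for this flat result.

As far as these compounds go, whether a chloro or methoxy group on the phenyl ring of the anilino group, or a basic amine on a longer chain at this place, would give a step beyond the scatter remains open. Also open, from the compounds shown here alone, is whether the same flat picture holds in other cell lines.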